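The compounds below may be only part of what the source reports. "The series", "measured", "known", "first", "only" and "open" are said of these compounds alone.

In a physicochemical assay for solubility, measured as kinetic solubility (a lower number here means a less soluble compound, a higher number a more soluble compound), compound 1 `C[C@@H]1CN(c2ccc(OCc3ccccc3)c(C(=O)Nc3ccnnc3)c2)C[C@H](C)O1` gives 29000 nM. For compound 2 `N#CC1CCN(c2ccc(OCc3ccccc3)c(C(=O)Nc3ccnnc3)c2)CC1` the result is only a limit, < 1000 nM. Compound 3 `CN1CC2(CCN(c3ccc(OCc4ccccc4)c(C(=O)Nc4ccnnc4)c3)CC2)C1` replaces the 4-cyanopiperidin-1-yl group of compound 2 on the same aromatic carbon: a group of 10 heavy atoms (8 carbon, 2 nitrogen; one four-membered non-aromatic ring with 1 hetero atom, one six-membered non-aromatic ring with 1 hetero atom) in place of a group of 8 heavy atoms (6 carbon, 2 nitrogen; one six-membered non-aromatic ring with 1 hetero atom), on an aromatic carbon. Going by the values given here, the only measured step at this carbon is large: an at least 29-fold lower number from compound 1 to compound 2 (1.46 log units; beyond the scatter). That single step shows how far the number can move with the group at this place, so a large upward step is expected in this assay, though with wide uncertainty. The expected change is an at least 12-fold higher number from compound 2 to compound 3 (1.07 log units; beyond the scatter). For compound 3 the estimated value is 12000 nM, with an expected range of 2000 nM to 60000 nM.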

Compound 3, solubility: 266000 nM
For compound 3 the middle estimate is 22-fold (1.35 log units) below the measured one, and the stated range ends below it.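

At this aromatic carbon, the group with one four-membered and one six-membered non-aromatic ring sets compound 3 above both others in this assay: the change is an at least 260-fold higher number from compound 2 to compound 3 (2.42 log units; beyond the scatter), and a 9.2-fold higher number from compound 1 to compound 3 (0.96 log units; beyond the scatter). The number at this position therefore moves in both directions with the group, not only downward. Compound 2 is a limit, so its step gives only a bound: the limit of < 1000 nM in this assay, at which 1 of the 3 values shown sits.

Which part of the entering group goes with the rise stays open. Also open, from the compounds shown here alone, is how a dimethylamino group or a carboxylic acid would read at this carbon.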